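Replacing hydroxy with chloro on the compound 3 ring

The compounds below may be only part of what the source reports. "The series", "measured", "known", "first", "only" and "open" are said of these compounds alone.

- compound 1 `C[C@@H](/N=c1\c(O)c(O)\c1=N/c1ccc(C#N)cc1)C(C)(C)C` gives 370 nM; 24300 nM (2 entries)
- compound 2 `COc1cc(C#N)ccc1/N=c1\c(O)c(O)\c1=N/[C@H](C)C(C)(C)C` gives 290 nM
- compound 3 `C[C@@H](/N=c1\c(O)c(O)\c1=N/c1ccc(C#N)cc1O)C(C)(C)C` gives 6050 nM
- compound 4 `C[C@@H](/N=c1\c(O)c(O)\c1=N/c1ccc(C#N)cc1Cl)C(C)(C)C` is not yet measured

In a functional assay for inhibition, with Rattus norvegicus as the target (on this read-out lower numbers stand for stronger inhibition and higher numbers for weaker inhibition), compound 3 stands highest of the two compounds with a single number. Compound 1 offers no single number, as its two entries lie far apart (the several entries of compound 1 in this assay, 370 nM; 24300 nM (2 entries)). Compound 4 differs from compound 3 by chloro in place of hydroxy on an aromatic carbon. Going by the values given here, one measured step bears directly on this change. It ends at the same hydroxy group and runs a 21-fold higher number from compound 2 to compound 3 (1.32 log units; beyond the scatter), a large step beyond the scatter. Among the compounds with values here, no measured compound yet carries chloro, so the read-across is loose. The expectation rests on compound 2 at 290 nM, where the hydroxy group is absent, and a clear move to a lower number is therefore expected in this assay. The estimated step runs an 8.6-fold lower number from compound 3 to compound 4 (0.94 log units; beyond the scatter), probably somewhat smaller than the measured one. For compound 4 the estimate is 700 nM, with 130 nM to 3800 nM as the expected range.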

Compound 4, half-maximal inhibitory concentration: 41 nM
Estimate against measurement, compound 4: 17-fold (1.23 log units) above; the whole stated range lies above it.
By their numbers in this assay, from the lowest: compound 4; then compound 2; then compound 3.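

In this assay, the change from hydroxy to chloro on this aromatic carbon gives a 150-fold lower number from compound 3 to compound 4 (2.17 log units; beyond the scatter), so the position can move the read-out further than the earlier step from methoxy to hydroxy had shown. The second comparison gives a 7.1-fold lower number from compound 2 to compound 4 (0.85 log units; beyond the scatter), so chloro reads lower than methoxy as well as hydroxy. The earlier compounds had shown only a loss on going from methoxy to hydroxy, whereas these steps show that this position can also yield a number well below that of compound 2.

Compound 1 carries only hydrogen on this carbon, and whether chloro improves on it stays unsettled, as its entries lie far apart: the several entries of compound 1 in this assay, 370 nM; 24300 nM (2 entries). On these data alone, how a fluoro, a bromo, a methyl or an amine on this carbon would read also remains open.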